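From Fluorine to Chlorine on the Amine-Bound Phenyl

The source may hold more compounds than are shown below. What is called first, only, known or untested is meant among the compounds shown, and "the series" means these compounds.

Compound 2 `O=C(CCCN1CCN(c2ccc(F)cc2)CC1)Nc1ccc(Cl)cc1` gives 76.1% in an assay on HEK293 cells for inhibition of Voltage-dependent T-type calcium channel subunit alpha-1G (Homo sapiens), read by patch clamp, tested at 10 uM; a higher number here means more inhibition at the concentration tested (going by the name of the read-out), a lower number less inhibition. Going by the values given here, of the two numbers measured so far it is the lower one, but its only neighbour, compound 1 `O=C(CCCN1CCN(c2ccccc2F)CC1)Nc1ccc(Cl)cc1`, gives 79.2% in this assay, and the step of a number 3.1 percentage points lower from compound 1 to compound 2 (within the scatter) lies within the scatter, so the two compounds cannot be told apart on these data.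

The unmeasured compound 3 `O=C(CCCN1CCN(c2ccccc2Cl)CC1)Nc1ccc(Cl)cc1` differs from compound 2 in a single place: 2-chlorophenyl in place of 4-fluorophenyl on an amine nitrogen in a ring. Among the compounds with values here, only one measured step bears on this change, namely a number 3.1 percentage points lower from compound 1 to compound 2 (within the scatter), which exchanged a 2-fluorophenyl for a 4-fluorophenyl on the same amine nitrogen in a ring and remained within the scatter. Within the data shown here, compound 3 returns to a 2-substituted phenyl on that nitrogen, but with chlorine where compound 1 carried fluorine; no measured pair covers such a fluorine-to-chlorine exchange.

The step of a number 2.9 percentage points higher from compound 2 to compound 3 (within the scatter) is therefore expected to be small, leaning if at all toward the number of compound 1. For compound 3 the estimate in this assay is 79%, with a range from 65% to 90%.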

Compound 3, a percentage reported as inhibition, at one concentration (the size of the read-out at that concentration, not a potency): 60.5%
For compound 3 the middle estimate is 18.5 percentage points above the measured one, outside the stated range (below it).
By their numbers in this assay, from the lowest: compound 3; then compounds 2 and 1 (each within the scatter of the next).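

Going by these compounds alone, at this place on the amine nitrogen in a ring, the identity of the halogen counts for more than anything the earlier pair revealed: in this assay, chloro in place of fluoro on an aromatic carbon gives a number 18.7 percentage points lower from compound 1 to compound 3 (beyond the scatter) and marks the first change to clear the scatter. The exchange of 4-fluorophenyl for 2-chlorophenyl gives a number 15.6 percentage points lower from compound 2 to compound 3 (beyond the scatter) and so sets compound 3 apart from both fluorine-bearing compounds. By contrast, the step of a number 3.1 percentage points lower from compound 1 to compound 2 (within the scatter) lies within the scatter, and 2-fluorophenyl in compound 1 shows that a group at the 2-position is not enough by itself to lower the number. No measured evidence is available here to explain the difference between the two halogens.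

Going by these compounds, it remains open whether 4-chlorophenyl would track 2-chlorophenyl or 4-fluorophenyl, and thus whether the drop belongs to chlorine generally or only to chlorine at the 2-position. How 2-bromophenyl or 2-methoxyphenyl would fare on the same nitrogen, and whether the step would survive a longer chain in the shared core, also stays unresolved.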